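Methyl for Chloro on the Urea Aryl Ring

This account rests on a few compounds, and the source may have more. Where it says the series, first, only, none or still open, it means among the compounds named here.

Compound 1, `CN(C)CCCNc1nc(-c2ccc(NC(=O)Nc3ccc(Cl)cc3)cc2)nc2c(Cl)c(Cl)sc12`, in a functional assay on MDA-MB-231 cells (Homo sapiens) for cytotoxicity, read by MTT assay, with a stated time of 72 h (on this read-out higher numbers stand for weaker inhibition and lower numbers for stronger inhibition), gives 1160 nM.
Compound 2, `CN(C)CCNc1nc(-c2ccc(NC(=O)Nc3ccc(Cl)cc3)cc2)nc2c(Cl)c(Cl)sc12`, gives 870 nM.
Compound 3, `CCN(CC)CCCNc1nc(-c2ccc(NC(=O)Nc3ccc(Cl)cc3)cc2)nc2c(Cl)c(Cl)sc12`, gives 660 nM.

All three share one core and one urea terminus and differ only in the amine-bearing chain. Compound 3 gives the smallest of the three numbers, yet every step separating it from the others sits within the scatter: a 1.3-fold lower number from compound 2 to compound 3 (0.12 log units; within the scatter) and a 1.8-fold lower number from compound 1 to compound 3 (0.24 log units; within the scatter), just as a 1.3-fold lower number from compound 1 to compound 2 (0.12 log units; within the scatter) does. On these numbers the three compounds cannot be told apart.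

Compound 4, `CCN(CC)CCCNc1nc(-c2ccc(NC(=O)Nc3ccc(C)cc3)cc2)nc2c(Cl)c(Cl)sc12`, keeps the diethylamino chain of compound 3 and changes the far end of the molecule instead: methyl in place of chloro on an aromatic carbon. Among the compounds with values here, no measured step touches this ring; the three steps recorded all concern the chain on the other side of the core, and all three stayed within the scatter. Within the data shown here, there is therefore no measured step from which a shift in this assay can be read for this change, and the expectation is that a 1.4-fold higher number from compound 3 to compound 4 (0.13 log units; within the scatter) stays within the scatter of compound 3. Compound 4 is accordingly estimated at 900 nM, with a range from 300 nM to 2700 nM, the width reflecting the absence of any directly comparable step.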

Compound 4, half-maximal inhibitory concentration: 3040 nM
Compound 4: the middle estimate sits 3.4-fold (0.53 log units) below what was measured; measured number outside the range, above it.
By their numbers in this assay, from the lowest: compounds 3, 2 and 1 (each within the scatter of the next); then compound 4.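

Within the data shown here, the urea aryl ring is the first place where a single change moves the number in this assay beyond the scatter: a 4.6-fold higher number from compound 3 to compound 4 (0.66 log units; beyond the scatter), with methyl in place of chloro on an aromatic carbon, para to a large group. Among these compounds, the exchange is one heavy atom for one heavy atom, with no hydrogen-bond donor or acceptor and no net charge on either side, yet it is the only recorded step to leave the scatter, whereas all the steps along the amine-bearing chain stayed within it. The step is modest and rests on a single pair, but it shows that the number responds to this position even though the chain differences measured so far could not separate the compounds. Nothing available explains why the methyl compound gives the higher number.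

The compounds shown leave open whether the same exchange would carry over to the dimethylamino chains of compound 1 and compound 2. They also leave open how other groups at this position, such as fluoro, methoxy or trifluoromethyl, would compare with chloro and methyl.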